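The source may report more compounds than this note shows. Statements on the series, on what has been measured and on what is new or still open speak of the compounds shown alone.

Compound 2, `O=C(O)c1ccc(S(=O)(=O)Nc2ccc(NS(=O)(=O)c3ccc(F)cc3)cc2)cc1`, carries a carboxy group on an aromatic carbon. In an assay for inhibition of liver carboxylesterase 1 (Homo sapiens), read by spectrophotometry (a higher number here means a weaker inhibitor, a lower number a stronger inhibitor), compound 2 gives > 100000 nM, which is a limit of the assay and not a number. Compound 1, `Cc1ccc(S(=O)(=O)Nc2ccc(NS(=O)(=O)c3ccc(F)cc3)cc2)cc1`, differs from compound 2 only by having methyl in place of carboxy at that carbon. In this assay compound 1 gives > 100000 nM, again a limit rather than a number. Both values sit at the limit of > 100000 nM in this assay, at which 2 of the 2 values shown sit, so the step that the two limits leave unreadable from compound 1 to compound 2 cannot be read in size or in direction. Compound 3, `O=S(=O)(Nc1ccc(NS(=O)(=O)c2ccc(F)cc2)cc1)c1ccc(F)cc1`, has not yet been measured; it differs from compound 2 by fluoro in place of carboxy on an aromatic carbon, so that compound 3 carries two 4-fluorophenyl groups. Within the data shown here, the only measured step that bears on this change is itself unreadable, so no step of known size is available to guide the expectation. The expected step of a number no higher from compound 2 to compound 3 (the limit leaves the size open) is therefore none beyond the scatter, and compound 3 is expected most likely to be reported again only as a limit in this assay. The estimate for compound 3 in this assay is 100000 nM, with an expected range from 30000 nM to 300000 nM.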

Compound 3, inhibition constant: > 100000 nM
Compound 3 ended at the assay's limit; the forecaster's own chance of this, stated with the estimate: 75%; the middle value sits exactly at the limit.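

Among these compounds, no step among compound 1, compound 2 and compound 3 can be read, in size or in direction, because all three values are limits of the assay and not numbers: the limit of > 100000 nM in this assay, at which 3 of the 3 values shown sit. The compounds shown leave open whether any group at this aromatic carbon would give a readable value in this assay.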